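Working notes: the step from compound 2 to compound 3

The source may report more compounds than this note shows. Statements on the series, on what has been measured and on what is new or still open speak of the compounds shown alone.

Two members of the series have been read so far in a functional assay on PC-3 cells (Homo sapiens) for cytotoxicity, read by MTT assay, with a stated time of 24 h; on this read-out higher numbers stand for weaker inhibition and lower numbers for stronger inhibition. Compound 1 (`O=C1/C(=C/c2ccccc2F)CN(C(=S)SCc2cn(Cc3ccccc3Cl)nn2)C/C1=C\c1ccccc1F`) gives > 80000 nM, which is a limit of the assay and not a number. Compound 2 (`Cc1ccc(/C=C2\CN(C(=S)SCc3cn(Cc4cccc(Cl)c4)nn3)C/C(=C\c3ccc(C)cc3)C2=O)cc1`) gives > 80000 nM, which is also a limit. Compound 2 therefore stands at the limit of > 80000 nM in this assay, at which 2 of the 2 values shown sit.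

Compound 3 (`Cc1ccc(/C=C2\CN(C(=S)SCc3cn(Cc4ccccc4Cl)nn3)C/C(=C\c3ccc(C)cc3)C2=O)cc1`) has not yet been measured. Its change from compound 2 is 2-chlorophenyl in place of 3-chlorophenyl on a saturated chain carbon bound to an aromatic nitrogen. Among the compounds with values here, no measured step is available to scale this change. In this assay, the expected step, an at least 1.0-fold lower number from compound 2 to compound 3 (0.02 log units; that floor lies within the scatter), is none beyond the scatter, with neither direction favoured. A further reading at the limit of the assay is the likeliest outcome. For compound 3 the estimated value is 75000 nM, with an expected range from 35000 nM to 120000 nM.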

Compound 3, half-maximal inhibitory concentration: > 80000 nM
Compound 3 was reported as a limit; the forecaster's own chance of this, stated with the estimate: 75%; at least 1.0-fold (0.02 log units) between middle value and limit.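

Within the data shown here, compound 3 reads as a limit of the assay, as compound 2 does, so no step between compound 2 and compound 3 can be read. The compounds shown leave open how 2-chlorophenyl and 3-chlorophenyl compare, and whether any member of the series gives a value inside the assay's range: the limit of > 80000 nM in this assay, at which 3 of the 3 values shown sit.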